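Pyrazole to Pyridine on the Fused Ring: Compound 4

The source may report more compounds than this note shows. Statements on the series, on what has been measured and on what is new or still open speak of the compounds shown alone.

Compound 1 `Cc1cc(-c2c(C)nn(C)c2C)ccc1-c1nnc(N(C)Cc2ccc3ncc(-c4cnn(C)c4)n3c2)o1`: 63.1 nM
Compound 2 `Cc1cc(-c2c(C)nn(C)c2C)ccc1-c1nnc(N(C)Cc2ccc3ncc(-c4cnn(CCN(C)C)c4)n3c2)o1`: 126 nM
Compound 3 `Cc1cc(-c2c(C)nn(C)c2C)cnc1-c1nnc(N(C)Cc2ccc3ncc(-c4cnn(CCN(C)C)c4)n3c2)o1`: 1000 nM

In an assay on COS-7 cells for inhibition of tyrosine-protein kinase receptor UFO (Homo sapiens), read by ELISA, with a stated time of 1 h (a lower number here means a stronger inhibitor, a higher number a weaker inhibitor), compound 3 gives the highest number of the three measured; compound 2 gives 126 nM and compound 1 gives 63.1 nM, both lower by margins beyond the scatter. Compound 4 `Cc1cc(-c2c(C)nn(C)c2C)cnc1-c1nnc(N(C)Cc2ccc3ncc(-c4ccc(CN(C)C)nc4)n3c2)o1` differs from compound 3 by 6-((dimethylamino)methyl)pyridin-3-yl in place of 1-(2-(dimethylamino)ethyl)-1H-pyrazol-4-yl on an aromatic carbon. Going by the values given here, the only measured step that touches this part of the molecule is a 2.0-fold higher number from compound 1 to compound 2 (0.30 log units; within the scatter), a change within the scatter. No measured pair swaps the five-membered ring for a six-membered one, so that part of the change has no precedent among these compounds. Compound 4 is therefore expected to stay close to compound 3, with a step of no change at the digits printed from compound 3 to compound 4 (within the scatter) foreseen and nothing beyond the scatter. Compound 4 is estimated at 1000 nM, between 300 nM and 3200 nM.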

Compound 4, half-maximal inhibitory concentration in the tyrosine-protein kinase receptor UFO assay: 1580 nM
Compound 4: middle estimate off by 1.6-fold (0.20 log units), on the low side; low and high end bracket the measured number.
By their numbers in the tyrosine-protein kinase receptor UFO assay, from the lowest: compounds 1 and 2 (each within the scatter of the next); then compounds 3 and 4 (each within the scatter of the next).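

In the tyrosine-protein kinase receptor UFO assay, compound 3 gives 1000 nM and compound 4 gives 1580 nM with 6-((dimethylamino)methyl)pyridin-3-yl in place of 1-(2-(dimethylamino)ethyl)-1H-pyrazol-4-yl; the exchange gives a 1.6-fold higher number from compound 3 to compound 4 (0.20 log units; within the scatter), so in this pair a six-membered aromatic ring stands in for a five-membered one without a change beyond the scatter. In a physicochemical assay for lipophilicity, at pH 7.4 (on this read-out lower numbers stand for lower lipophilicity and higher numbers for higher lipophilicity), compound 3 gives 2.7 and compound 4 gives 2.5 and the same exchange gives a number 0.20 log units lower from compound 3 to compound 4 (within the scatter). No evidence at hand bears on this result.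

Open, as far as these compounds go, is whether the exchange reads the same way on the core of compound 2. Also open, from the compounds shown here alone, is how a morpholine or a carboxylic acid in place of the dimethylamino group would read.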